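The compounds below may be only part of what the source reports. "The series", "measured", "known", "first", "only" and "open" are said of these compounds alone.

Working notes on the series. In a functional assay on HCT-116 cells (Homo sapiens) for antiproliferative activity, read by MTT assay, with a stated time of 72 h (on this read-out higher numbers stand for weaker inhibition and lower numbers for stronger inhibition), compound 1 (`NC1=NC2(CCSCC2)N(OCCCOc2ccc(Cl)c(Cl)c2)C(N)=N1`) gives 1 nM, compound 2 (`NC1=NC2(CCSCC2)N(OCCCOc2cccc(Cl)c2Cl)C(N)=N1`) gives 1 nM and compound 3 (`NC1=NC2(CCSCC2)N(OCCCOc2cccc(Br)c2)C(N)=N1`) gives 1 nM. Compound 3 therefore stands level with the other two measured compounds.

The next compound is compound 4 (`NC1=NC2(CCSCC2)N(OCCCOc2ccc(Cl)cc2)C(N)=N1`). Its difference from compound 3 is 4-chlorophenyl in place of 3-bromophenyl on an oxygen on a saturated carbon, which amounts to 4-chlorophenyl in place of 3-bromophenyl on an oxygen on a saturated carbon. The shared core and the chain stay as they are.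

Within the data shown here, three measured steps bear on this, as each alters the same substituted phenyl on an oxygen on a saturated carbon. They read no change at the digits printed from compound 1 to compound 2 (within the scatter), no change at the digits printed from compound 1 to compound 3 (within the scatter) and no change at the digits printed from compound 2 to compound 3 (within the scatter). None of them leaves the scatter. However, no measured compound carries the 4-chlorophenyl group, and three equal values show little of how far such a change could reach.

No step beyond the scatter is therefore expected in this assay, though a small drift towards weaker inhibition cannot be excluded. The expected size is a 1.5-fold higher number from compound 3 to compound 4 (0.18 log units; within the scatter). For compound 4 the estimated value is 1.5 nM, with an expected range of 0.6 nM to 5 nM.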

Compound 4, half-maximal inhibitory concentration: 10 nM
Estimate against measurement, compound 4: 6.7-fold (0.82 log units) below; measured number outside the range, above it.
By their numbers in this assay, from the lowest: compounds 1, 2 and 3 (each within the scatter of the next); then compound 4.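

The group on the oxygen on a saturated carbon can matter in this assay: the equal values of the first three compounds did not show this, but 4-chlorophenyl gives a 10-fold higher number from compound 3 to compound 4 (1.00 log units; beyond the scatter) and, against 2,3-dichlorophenyl, a 10-fold higher number from compound 2 to compound 4 (1.00 log units; beyond the scatter) as well. The plainest comparison is hydrogen in place of chloro on an aromatic carbon, which turns 3,4-dichlorophenyl into 4-chlorophenyl and gives a 10-fold higher number from compound 1 to compound 4 (1.00 log units; beyond the scatter), so the chloro that remains in 4-chlorophenyl does not by itself keep the level of compound 1. The number of halogens does not sort these compounds, since compound 3 and compound 4 each carry one yet stand apart, and no measurement on hand accounts for the step.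

From the compounds shown here alone, it remains open whether 3-chlorophenyl would stay level with compound 3 or move towards compound 4, and so whether the identity of the halogen or its place on the ring is what separates them. Unsubstituted phenyl and 4-bromophenyl would test the same question, and a methoxy group on the phenyl would show whether a group other than a halogen can hold the level of compounds 1, 2 and 3.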